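A few compounds are considered here, and "the series" means these few. Any claim that something is new, unique, unknown or untested is made for them only; others in the source may bear on it.

Compound 2 `CC(=O)OCc1cc(=O)n(-c2ccccc2)s1` is the weaker of the two numbered measurements in an assay for inhibition of histone acetyltransferase KAT2B (Homo sapiens) (on this read-out lower numbers stand for stronger inhibition and higher numbers for weaker inhibition), where compound 2 gives 162000 nM. Its nearest neighbour on this read-out is compound 1 `O=c1ccsn1-c1ccccn1`, which in this assay gives 19000 nM, a gap that lies beyond the scatter of repeated measurements. The third member of the set, compound 3 `O=C(Nc1ccccc1)OCc1cc(=O)n(-c2ccccc2)s1`, reaches only the limit of this assay and gives > 200000 nM, a limit rather than a number. The step from compound 2 to compound 3 reads an at least 1.2-fold higher number from compound 2 to compound 3 (0.09 log units; that floor lies within the scatter), so the replacement of methyl by anilino on the carbonyl carbon did not sharpen inhibition; the floor of that step is set by the limit of > 200000 nM in this assay, at which 1 of the 3 values shown sits.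

The unmeasured compound 4 `Cc1cc(=O)n(-c2ccccc2)s1` differs from compound 2 by hydrogen in place of acetoxy on a saturated chain carbon bound to an aromatic carbon. None of the measured steps strips the acetoxy away: the only step shown alters the carbonyl substituent while keeping the ester in place, and compound 1 differs from compound 2 in more than one position. Without a comparable step, compound 4 is expected to stay close to compound 2, with a step of a 1.6-fold lower number from compound 2 to compound 4 (0.21 log units; within the scatter) in this assay. Compound 4 is therefore estimated at 100000 nM, within a range from 30000 nM to 300000 nM.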

Compound 4, half-maximal inhibitory concentration: > 200000 nM
Compound 4: no number, only a limit; the forecaster's own chance of this, stated with the estimate: 25%; middle value at least 2.0-fold (0.30 log units) from the limit.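

In this assay, on these data alone, the change from acetoxymethyl to methyl, on a saturated chain carbon bound to an aromatic carbon, reads an at least 1.2-fold higher number from compound 2 to compound 4 (0.09 log units; that floor lies within the scatter), so this step has only a floor and its true size stays unknown. Compound 4 gives > 200000 nM, which is a limit and not a number. The earlier step altered only the carbonyl substituent and kept the ester in place, whereas this one takes the whole acetoxy away, and it shows that losing the ester altogether brings no measurable number at this position, so both changes made here from compound 2 end at the same limit: the limit of > 200000 nM in this assay, at which 2 of the 4 values shown sit.

Still open, as far as these compounds go, is whether an amine, a carboxylic acid or a longer chain in place of acetoxy at this position would give a number inside the range of the assay. Also open, from the compounds shown here alone, is how far beyond the limit compound 3 and compound 4 lie, and so whether the anilino change and the loss of acetoxy differ at all.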